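The compounds below may be only part of what the source reports. "The series", "measured", "known", "first", "only" and "open" are said of these compounds alone.

Two compounds have been measured in an assay on isolated protein for inhibition of DNA topoisomerase 1 (Homo sapiens), tested at 100 uM; a higher number here means a stronger effect of the compound at the concentration tested, a lower number a weaker effect:
compound 1, `Cc1ccc(-c2cc(-c3ccc(Cl)o3)cc(-c3ccsc3)n2)o1`, giving 9.1%;
compound 2, `Cc1ccc(-c2cc(-c3ccoc3)cc(-c3ccsc3)n2)cc1`, giving 13.2%.

The two numbers sit close together, and the gap between compound 1 and compound 2 lies within the usual scatter of repeated measurements of this kind, so neither stands apart from the other; both show only weak inhibition at the concentration tested. Compound 3, `Clc1ccc(-c2cc(-c3ccsc3)nc(-c3ccco3)c2)o1`, has not yet been measured. It differs from compound 1 in one place: hydrogen in place of methyl on an aromatic carbon. Within the data shown here, no pair of measured compounds separated by a single change is available, so the size of such a step cannot be read from the data. The removal of one methyl is expected to move this assay little, and the step from compound 1 to compound 3 is estimated at a number 0.9 percentage points higher from compound 1 to compound 3 (within the scatter), no more than the scatter. Compound 3 is therefore expected to give about 10%, within a range of 2% to 22%.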

Compound 3, a percentage reported as inhibition, at one concentration (the size of the read-out at that concentration, not a potency): 8.2%
Estimate against measurement, compound 3: 1.8 percentage points above; measured number inside the range.
By their numbers in this assay, from the lowest: compounds 3, 1 and 2 (each within the scatter of the next).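

Among these compounds, compound 1 and compound 3 form the first measured pair that differs in one place, so the size of a single change can now be read. Going from 5-methylfuran-2-yl to furan-2-yl, on the carbon next to the ring oxygen, gives a number 0.9 percentage points lower from compound 1 to compound 3 (within the scatter) in this assay and so methyl and hydrogen at this place cannot be told apart by this read-out. No measurement available here explains this result.

Going by these compounds, only hydrogen and methyl have been seen at this place, so it remains open whether a longer chain such as propyl, an amine or a carboxylic acid there would give a clearly different number. On these data alone, it is also open whether the same swap would have as small an effect on a compound with much stronger inhibition.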